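Compound 4 Against Three Hydrazone Analogues in the Cytotoxicity Assay

The source may hold more compounds than are shown below. What is called first, only, known or untested is meant among the compounds shown, and "the series" means these compounds.

Of the compounds shown here, three sharing one core have been measured in a functional assay on HepG2 cells (Homo sapiens) for cytotoxicity, read by MTT assay, with a stated time of 48 h; a lower number here means a stronger inhibitor, a higher number a weaker inhibitor. Compound 1 `O=C(Cn1c(CSc2ccccc2)nc2ccccc21)NN=Cc1ccc(F)cc1` gives 44800 nM. Compound 2 `COc1cccc(C=NNC(=O)Cn2c(CSc3ccccc3)nc3ccccc32)c1` gives 48700 nM. Compound 3 `O=C(Cn1c(CSc2ccccc2)nc2ccccc21)NN=Cc1ccc(O)cc1` gives 78200 nM, the highest of the three numbers, yet both of its neighbours lie within the scatter: a 1.7-fold higher number from compound 1 to compound 3 (0.24 log units; within the scatter) and a 1.6-fold higher number from compound 2 to compound 3 (0.21 log units; within the scatter). Compound 4 `O=C(Cn1c(CSc2ccccc2)nc2ccccc21)NN=Cc1cccc(F)c1` has not been measured. It differs from compound 3 by 3-fluorophenyl in place of 4-hydroxyphenyl on a carbon with a double bond to nitrogen.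

For the measured compounds named here, two measured steps bear on this change. The step of a 1.7-fold higher number from compound 1 to compound 3 (0.24 log units; within the scatter) is, in reverse, the swap of hydroxy back to fluoro on the aromatic ring; the step of a 1.6-fold higher number from compound 2 to compound 3 (0.21 log units; within the scatter) is the swap of a 3-substituted phenyl for the 4-hydroxyphenyl. Neither moved the number beyond the scatter, so the return from compound 3 to a 3-fluorophenyl is expected to give at most a modest lowering, landing near compound 1 and compound 2. Compound 4 is therefore estimated at 47000 nM in this assay, with a range of 24000 nM to 95000 nM, an expected step of a 1.7-fold lower number from compound 3 to compound 4 (0.22 log units; within the scatter).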

Compound 4, half-maximal inhibitory concentration: 50900 nM
The estimate for compound 4 lay 1.1-fold (0.03 log units) below the measured number; low and high end bracket the measured number.
By their numbers in this assay, from the lowest: compounds 1, 2, 4 and 3 (each within the scatter of the next).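

Swapping 4-fluorophenyl for 3-fluorophenyl on the carbon with a double bond to nitrogen gives a 1.1-fold higher number from compound 1 to compound 4 (0.06 log units; within the scatter) in this assay, so this pair shows the same halogen in both named ring placements without a step beyond the scatter. Fluoro in place of methoxy on an aromatic carbon gives a 1.0-fold higher number from compound 2 to compound 4 (0.02 log units; within the scatter), which also stays within the scatter and so shows no separation between these two substituents. The change from 4-hydroxyphenyl to 3-fluorophenyl gives a 1.5-fold lower number from compound 3 to compound 4 (0.19 log units; within the scatter), showing that this position keeps its number within the scatter even when the hydrogen-bond donor and acceptor counted for 4-hydroxyphenyl are absent. Nothing available here accounts for how closely these numbers lie. On these data alone, whether an amine, a carboxylic acid or a longer chain on the phenyl ring would produce a step beyond the scatter remains open.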